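The compounds below may be only part of what the source reports. "The series", "measured", "known", "first", "only" and "open" are said of these compounds alone.

The compounds with numbers in hand:

Compound 1, `C=C1CC[C@@H]2[C@](C)(CO)[C@H](O)CC[C@@]2(C)[C@@H]1CCC1C(=O)OC[C@H]1O`, gives 34.2% in an assay on isolated protein for inhibition of Maltase-glucoamylase (Homo sapiens), tested at 100 uM; on this read-out higher numbers stand for more inhibition at the one concentration tested (going by the name of the read-out) and lower numbers for less inhibition.
Compound 2, `C=C1CC[C@@H]2[C@](C)(CO)[C@H](O)CC[C@@]2(C)[C@@H]1/C=C/C1=C/C(=C/CCC)OC1=O`, gives 43.5%.
Compound 3, `C=C1CC[C@@H]2[C@](C)(CO)[C@H](O)CC[C@@]2(C)[C@@H]1/C=C/C1=C/C(=C/c2cccc(Br)c2)OC1=O`, gives 16.7%.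

Compound 2 has the highest of the three numbers, yet its gap to compound 1 lies within the usual scatter, and only its gap to compound 3 lies beyond it. Compound 4, `C=C1CC[C@@H]2[C@](C)(CO)[C@H](O)CC[C@@]2(C)[C@@H]1/C=C/C1=C/C(=C/C=C/c2ccccc2)OC1=O`, differs from compound 2 in one place: 2-phenylethenyl in place of propyl on a double-bonded chain carbon bound to a double-bonded ring carbon. For the measured compounds named here, the one step that bears on this is a number 26.8 percentage points lower from compound 2 to compound 3 (beyond the scatter), where an aromatic ring also entered at the same place. Going by the values given here, compound 4 brings in an aromatic ring as well, so a drop in this assay of comparable size is expected, though the single comparison leaves the size uncertain. Compound 4 is therefore estimated at 22%, within 8% to 38%, which means an expected step of a number 21.5 percentage points lower from compound 2 to compound 4 (beyond the scatter).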

Compound 4, a percentage reported as inhibition, at one concentration (the size of the read-out at that concentration, not a potency): 84.3%
For compound 4 the middle estimate is 62.3 percentage points below the measured one; the whole stated range lies below it.
By their numbers in this assay, from the lowest: compound 3; then compounds 1 and 2 (each within the scatter of the next); then compound 4.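

In this assay, an aromatic ring at this place does not in itself lower the number: the change to 2-phenylethenyl is a number 40.8 percentage points higher from compound 2 to compound 4 (beyond the scatter), the opposite direction from a number 26.8 percentage points lower from compound 2 to compound 3 (beyond the scatter). The exchange of 3-bromophenyl for 2-phenylethenyl on the same double-bonded chain carbon is a number 67.6 percentage points higher from compound 3 to compound 4 (beyond the scatter), so the identity of the aromatic group matters greatly here. No evidence on the reason for this rise is at hand. Still open, from the compounds shown here alone, is whether the double bond of 2-phenylethenyl is needed, as a 2-phenylethyl group would test, and whether an amine or carboxylic acid on its ring keeps the number.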